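A Change on the Carbonyl Carbon of Compound 2

The source may report more compounds than this note shows. Statements on the series, on what has been measured and on what is new or still open speak of the compounds shown alone.

Of the compounds shown here, three sharing one core have been measured in a functional assay on IGROV-1 cells (Homo sapiens) for inhibition, read by sulforhodamine B assay, with a stated time of 48 h; on this read-out higher numbers stand for weaker inhibition of growth and lower numbers for stronger inhibition of growth. In this read-out, compound 1 `O=C(Nc1cccc(-n2cc(-c3ccncc3)c(-c3ccc(Cl)c(O)c3)n2)c1)Nc1cccc(C(F)(F)F)c1` gives 1640 nM, compound 2 `COc1cc(-c2nn(-c3cccc(NC(=O)Nc4ccc(Cl)c(Cl)c4)c3)cc2-c2ccncc2)ccc1Cl` gives 1180 nM and compound 3 `O=C(Nc1cccc(-n2cc(-c3ccncc3)c(-c3ccc(Cl)c(O)c3)n2)c1)Nc1ccc(Cl)c(Cl)c1` gives 1770 nM. Compound 2 is thus not separated from the other two, since all three numbers lie within the scatter of each other.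

Compound 4 `COc1cc(-c2nn(-c3cccc(NC(=O)c4ccc(Cl)c(C(F)(F)F)c4)c3)cc2-c2ccncc2)ccc1Cl` differs from compound 2 in one place, on a carbonyl carbon: 4-chloro-3-(trifluoromethyl)phenyl in place of (3,4-dichlorophenyl)amino on a carbonyl carbon. Going by the values given here, two measured steps bear on this change, though only in part. Placing 3,4-dichlorophenyl in place of 3-(trifluoromethyl)phenyl on an amide-type nitrogen gave a 1.1-fold higher number from compound 1 to compound 3 (0.03 log units; within the scatter). Placing hydrogen in place of methyl on an oxygen on an aromatic ring gave a 1.5-fold higher number from compound 2 to compound 3 (0.18 log units; within the scatter). Among the compounds with values here, neither step removes the (3,4-dichlorophenyl)amino group, and no measured compound carries 4-chloro-3-(trifluoromethyl)phenyl on the carbonyl carbon. With only these small steps as a guide, no change beyond the scatter is expected in this assay, and the range is kept wide for what the data lack. The expected size is a 1.0-fold higher number from compound 2 to compound 4 (0.01 log units; within the scatter), an estimate that stays within the scatter. For compound 4 the estimated value is 1200 nM, with an expected range from 400 nM to 3500 nM.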

Compound 4, concentration for 50% growth inhibition: 2150 nM
Compound 4: the middle estimate sits 1.8-fold (0.25 log units) below what was measured; measured number inside the range.
By their numbers in this assay, from the lowest: compounds 2, 1, 3 and 4 (each within the scatter of the next).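

In this assay, the replacement of (3,4-dichlorophenyl)amino by 4-chloro-3-(trifluoromethyl)phenyl on a carbonyl carbon gave a 1.8-fold higher number from compound 2 to compound 4 (0.26 log units; within the scatter). Going by these compounds alone, the earlier steps altered only the aromatic group on an amide-type nitrogen or the methyl on an oxygen, whereas this step is the first to remove the (3,4-dichlorophenyl)amino group itself, with 1 hydrogen-bond donor leaving and 0 entering, and for this one pair that exchange does not separate the two compounds beyond the scatter. Nothing available explains this outcome or links it to any property of either group.

Still open, from the compounds shown here alone, is how the nitrogen that leaves and the different groups on the aromatic ring each contribute, as both differ at once between compound 2 and compound 4, and a (4-chloro-3-(trifluoromethyl)phenyl)amino group on the carbonyl carbon would separate the two. Also open, going by these compounds, is whether the position would stay within the scatter with a group that has no aromatic ring, such as a piperidine or a longer alkyl chain on the carbonyl carbon.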